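The compounds below may be only part of what the source reports. "The series", "measured", "known", "first", "only" and "open" are said of these compounds alone.

Numbers in a functional assay on HEK-EM293 cells for agonist activity at Thyrotropin receptor (Homo sapiens), read by ELISA and cAMP accumulation, with a stated time of 1 h (on this read-out higher numbers stand for larger maximal responses and lower numbers for smaller maximal responses), for the measured compounds of the series:

Compound 1 `COc1ccc(C2Nc3ccc(O)cc3C(=O)N2Cc2ccccc2)cc1COc1ccc(NC(C)=O)cc1` gives 93.3%.
Compound 2 `COc1ccc(C2Nc3ccccc3C(=O)N2c2ccccc2)cc1COc1ccc(NC(C)=O)cc1` gives 75.1%.
Compound 3 `COc1ccc(C2NC(=O)c3ccccc3N2)cc1COc1ccc(NC(C)=O)cc1` gives 39.5%.

Compound 3 stands lowest of the three in this assay; compound 2 lies nearest to it and compound 1 furthest, both beyond the scatter. Going by the values given here, the only single-point step measured so far that touches the same position is the one from compound 2 to compound 3, hydrogen in place of phenyl on an amide-type nitrogen in a ring, which gave a number 35.6 percentage points lower from compound 2 to compound 3 (beyond the scatter). Between compound 1 and compound 3 there is no single-point step; their two values simply show that the substituted nitrogen goes with the higher number.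

The new compound 4 `COc1ccc(C2Nc3ccccc3C(=O)N2CCCN(C)C)cc1COc1ccc(NC(C)=O)cc1` carries 3-(dimethylamino)propyl in place of hydrogen on an amide-type nitrogen in a ring. Since the measured step from compound 2 to compound 3 shows that removing a group on that nitrogen lowered the maximal response sharply, putting a group back is expected to raise it, likely by a step of the same order. Compound 4 is therefore expected to reach about 70%, with a range from 45% to 95%. The implied step, a number 30.5 percentage points higher from compound 3 to compound 4 (beyond the scatter), is an estimate only.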

Compound 4, largest response reached (Emax), in percent of the reference or control that the assay uses: 10.1%
For compound 4 the middle estimate is 59.9 percentage points above the measured one, and the stated range ends above it.
By their numbers in this assay, from the lowest: compound 4; then compound 3; then compound 2; then compound 1.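

In this assay, going by these compounds alone, the earlier compounds left it possible that any group on the amide-type nitrogen in a ring would give a higher number than hydrogen, but 3-(dimethylamino)propyl in place of hydrogen gives a number 29.4 percentage points lower from compound 3 to compound 4 (beyond the scatter) and so goes against that reading. Set against phenyl, the same chain gives a number 65 percentage points lower from compound 2 to compound 4 (beyond the scatter), a drop that takes the series beyond the one seen for hydrogen in place of phenyl, a number 35.6 percentage points lower from compound 2 to compound 3 (beyond the scatter), so that among these three compounds the order on this nitrogen runs from phenyl through hydrogen to 3-(dimethylamino)propyl, and the identity of the group matters, not merely whether one is present. Nothing available here bears on what lies behind this order.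

Going by these compounds, it remains open whether the lower number goes with the dimethylamino group or with the propyl chain itself, and a plain butyl chain on this nitrogen would separate the two. On these data alone, it is also open whether a benzyl or pyridyl group on the core of compound 2 would stay close to compound 2 at 75.1%.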